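The compounds below may be only part of what the source reports. "The series", "measured", "known", "first", "only" and "open" are said of these compounds alone.

Compound 1 `O=C(CSc1nncnc1-c1ccccc1Cl)Nc1ccccc1` has been tested in an ADME assay on MT4 cells (Homo sapiens) for cytotoxicity, read by MTT assay (a higher number here means that more compound is tolerated, a lower number that less compound is tolerated), where compound 1 gives 127000 nM. Going by the values given here, the only other compound measured there, compound 2 `O=C(CSc1nncnc1-c1cccc2ccccc12)Nc1ccccc1Cl`, gives 63000 nM, and the gap between these two numbers lies within the scatter, so compound 1 stands alongside compound 2 rather than apart from it. Compound 3 `O=C(CSc1nncnc1-c1ccccc1Cl)Nc1ccccn1` has not yet been measured; it differs from compound 1 in one place: pyridin-2-yl in place of phenyl on an amide-type nitrogen. With no comparable change among the measured pair, the step of a 1.1-fold lower number from compound 1 to compound 3 (0.02 log units; within the scatter) is expected to stay within the scatter. Compound 3 is therefore estimated at 120000 nM, between 50000 nM and 250000 nM.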

Compound 3, half-maximal cytotoxic concentration: 172000 nM
Estimate against measurement, compound 3: 1.4-fold (0.16 log units) below; the range from low to high includes it.
By their numbers in this assay, from the lowest: compounds 2, 1 and 3 (each within the scatter of the next, the first and the last beyond it).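

In this assay the change to pyridin-2-yl in place of phenyl on an amide-type nitrogen gives a 1.4-fold higher number from compound 1 to compound 3 (0.13 log units; within the scatter) and so does not measurably shift how much compound is tolerated. At this position, adding a ring nitrogen and one hydrogen-bond acceptor therefore leaves the read-out unchanged within the scatter. No measured evidence bears on this result.
As far as these compounds go, whether an amine or a carboxylic acid in place of pyridin-2-yl on the amide-type nitrogen would move the number beyond the scatter remains open.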